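The source may report more compounds than this note shows. Statements on the series, on what has been measured and on what is new or still open speak of the compounds shown alone.

Working notes on the series.

Among the measured compounds shown here, compound 2 `CNc1ccc(C(=O)N2CCCCc3ccccc32)c(Cl)c1` gives 35 nM in an assay on HeLa cells for binding affinity to Vasopressin V2 receptor (Homo sapiens) (a lower number here means a stronger inhibitor, a higher number a weaker inhibitor), the highest of the three numbers so far. Compound 3 `CCN(CC)c1ccc(C(=O)N2CCCCc3ccccc32)c(Cl)c1` gives 19 nM in this assay; the change from compound 2 to compound 3, diethylamino in place of methylamino on an aromatic carbon, gave a 1.8-fold lower number from compound 2 to compound 3 (0.27 log units; within the scatter). Compound 1 `Cc1cc(N)ccc1C(=O)N1CCCCc2cc(Cl)ccc21` gives 4.1 nM in this assay; it differs from compound 2 in more than one place, so only the two values themselves can be compared.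

Compound 4 `O=C(c1ccc(-n2cccn2)cc1Cl)N1CCCCc2ccccc21` carries 1H-pyrazol-1-yl in place of methylamino on an aromatic carbon. For the measured compounds named here, the only measured step at this position, from compound 2 to compound 3, lay within the scatter, and no measured step exchanges an amine for a ring, so nothing in hand argues for a large move in either direction. Compound 4 is therefore expected near compound 2 in this assay, with a 1.1-fold higher number from compound 2 to compound 4 (0.06 log units; within the scatter) as the estimated step, and an estimated value of 40 nM spanning 10 nM to 160 nM.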

Compound 4, half-maximal inhibitory concentration: 8.8 nM
For compound 4 the middle estimate is 4.5-fold (0.66 log units) above the measured one; the measured number lies below the stated range.
By their numbers in this assay, from the lowest: compound 1; then compound 4; then compounds 3 and 2 (each within the scatter of the next).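

In this assay, this position, para to a large group, gives its first step beyond the scatter: 1H-pyrazol-1-yl in place of methylamino produces a 4.0-fold lower number from compound 2 to compound 4 (0.60 log units; beyond the scatter). The same ring in place of diethylamino produces a 2.2-fold lower number from compound 3 to compound 4 (0.33 log units; beyond the scatter), so a five-membered aromatic ring with 2 hetero atoms sits lower here than either amine, although the step between those two amines stayed within the scatter. No measurement in hand bears on the reason for these steps.

On these data alone, whether the steps follow the aromatic ring itself or the loss of the hydrogen-bond donor stays open, and a morpholine or a plain phenyl ring in this place would separate the two readings. As far as these compounds go, compound 1 at 4.1 nM differs from compound 4 in more than one place, so what the pyrazole would do on the core of compound 1 also stays open.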